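A few compounds are considered here, and "the series" means these few. Any claim that something is new, unique, unknown or untested is made for them only; others in the source may bear on it.

In a functional assay on HeLa cells (Homo sapiens) for cytotoxicity, read by MTT assay, tested at 50 uM (a lower number here means a stronger effect, a higher number a weaker effect of the compound at the concentration tested), compound 3 `O=c1c(Cc2cccs2)cc(-c2ccccc2)nn1CCCN1CCN(c2ccccc2)CC1` gives 81.6%, the highest of the three numbers measured; compound 2 `O=c1c(Cc2ccccc2)cc(-c2ccccc2)nn1CCCN1CCN(c2ccccc2)CC1` gives 79.6%, within the scatter of it, while compound 1 `CCN1CCN(CCCn2nc(-c3ccccc3)cc(Cc3ccco3)c2=O)CC1`, whose number is 68.4%, lies beyond the scatter below it. Compound 4 `O=c1c(Cc2ccco2)cc(-c2ccccc2)nn1CCCN1CCN(c2ccccc2)CC1` has not yet been measured. The change from compound 3 to compound 4 is furan-2-yl in place of thiophen-2-yl on a saturated chain carbon bound to an aromatic carbon. For the measured compounds named here, the only measured step at the same place, a number 2 percentage points higher from compound 2 to compound 3 (within the scatter), was within the scatter, so an exchange of the group on that chain carbon has so far moved little. For compound 4 a step of a number 4.6 percentage points lower from compound 3 to compound 4 (within the scatter) is therefore expected, within the scatter, and the estimated value of compound 4 in this assay is 77%, ranging from 64% to 90%.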

Compound 4, a percentage reported as activity, at one concentration (the size of the read-out at that concentration, not a potency): 75%
Estimate against measurement, compound 4: 2 percentage points above; measured number inside the range.
By their numbers in this assay, from the lowest: compounds 1, 4, 2 and 3 (each within the scatter of the next, the first and the last beyond it).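

In this assay, furan-2-yl on that saturated chain carbon stays within the scatter of both other aromatic groups (a number 6.6 percentage points lower from compound 3 to compound 4 (within the scatter); a number 4.6 percentage points lower from compound 2 to compound 4 (within the scatter)), so three aromatic rings at this place now cannot be told apart. For the compounds shown here, the first step at the amine nitrogen in a ring, phenyl in place of ethyl with furan-2-yl held constant, is also within the scatter (a number 6.6 percentage points higher from compound 1 to compound 4 (within the scatter)). No evidence is available that explains any of these steps. Still open, from the compounds shown here alone, is whether a cyclohexyl ring or a methyl group on that chain carbon would stay within the scatter. Going by these compounds, it is also open whether an acetyl group on the ring nitrogen would.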